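This account rests on a few compounds, and the source may have more. Where it says the series, first, only, none or still open, it means among the compounds named here.

Measured so far:
- compound 1 `COc1ccc(/C=C/c2cc(OC)cc(OC)c2/C=C/C(=O)c2cc3cc(OC)ccc3oc2=O)cc1`: in an assay on isolated protein for inhibition of Amine oxidase [flavin-containing] B (Homo sapiens), read by fluorescence, with a stated time of 15 min (a higher number here means a weaker inhibitor, a lower number a stronger inhibitor), compound 1 gives > 60000 nM, a limit of the assay rather than a number.
- compound 2 `COc1ccc(/C=C/c2cc(OC)cc(OC)c2/C=C/C(=O)c2cc3cc(Cl)ccc3oc2=O)cc1`: in this assay compound 2 gives > 60000 nM, again a limit.
- compound 3 `COc1ccc(/C=C/c2cc(OC)cc(OC)c2/C=C/C(=O)c2cc3cc(Br)cc(OC)c3oc2=O)cc1`: in this assay compound 3 gives > 60000 nM, also a limit.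

For the measured compounds named here, compound 2 therefore stands at the limit of > 60000 nM in this assay, at which 3 of the 3 values shown sit, where every value shown so far sits; no compound here has a readable number. Going by the values given here, the only step between two compounds that differ in one place, a step that the two limits leave unreadable from compound 1 to compound 2, runs from one limit to another and so cannot be sized.

Compound 4 `COc1ccc(/C=C/c2cc(OC)cc(OC)c2/C=C/C(=O)c2cc3cccc(C)c3oc2=O)cc1` differs from compound 2 by a group of 12 heavy atoms (10 carbon, 2 oxygen; one six-membered aromatic ring of carbon only, one six-membered aromatic ring with 1 hetero atom) in place of a group of 12 heavy atoms (9 carbon, 2 oxygen, 1 chlorine; one six-membered aromatic ring of carbon only, one six-membered aromatic ring with 1 hetero atom), on a carbonyl carbon. Among the compounds with values here, no measured step bears readably on this change, because all three results rest at the limit of > 60000 nM in this assay, at which 3 of the 3 values shown sit. Nothing therefore points to a change beyond the scatter in either direction, and the most that can be expected is another result at or near the limit. Compound 4 is estimated at 80000 nM, with a range from 20000 nM to 300000 nM. The expected step that the limit leaves unreadable from compound 2 to compound 4 is accordingly not expected to exceed the scatter.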

Compound 4, half-maximal inhibitory concentration: 20000 nM
Compound 4: middle estimate off by 4.0-fold (0.60 log units), on the high side, and the stated range covers the measured number.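

In this assay, exchanging the group on the carbonyl carbon gives an at least 3.0-fold lower number from compound 2 to compound 4 (0.47 log units; beyond the scatter), a change beyond the scatter and the first readable movement among these compounds. It shows that this place can respond: the group with 10 carbon and 2 oxygen atoms gives a real number, whereas the group with 9 carbon, 2 oxygen and 1 chlorine atoms gives only a limit. Compound 4 alone has left that limit: the limit of > 60000 nM in this assay, at which 3 of the 4 values shown sit.

The compounds shown do not tell which part of the exchanged group carries the step, and the true size of the step stays unknown. Nor do they tell how a group bearing an amine, a carboxylic acid or a longer chain would read at this place, or whether any of these would bring the number lower still.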